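An oxadiazole isomer swap on compound 2

The source may hold more compounds than are shown below. What is called first, only, known or untested is meant among the compounds shown, and "the series" means these compounds.

Two compounds have numbers in a functional assay on MIA PaCa-2 cells (Homo sapiens) for inhibition, read by MTT assay, with a stated time of 3 days; on this read-out lower numbers stand for stronger inhibition and higher numbers for weaker inhibition. Compound 1 `CCN(CC)C(=O)c1ccc(S(=O)(=O)N2CCC[C@@H](C(=O)N3CCN(c4nc(C(C)C)no4)CC3)C2)cc1` gives 70 nM, and compound 2 `CCN(CC)S(=O)(=O)c1ccc(S(=O)(=O)N2CCC[C@@H](C(=O)N3CCN(c4nnc(C(C)C)o4)CC3)C2)cc1` gives 1000 nM. Compound 2 therefore has the higher of the two numbers and is the weaker inhibitor of the pair, by a gap beyond the usual scatter.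

Compound 3 `CCN(CC)S(=O)(=O)c1ccc(S(=O)(=O)N2CCC[C@@H](C(=O)N3CCN(c4nc(C(C)C)no4)CC3)C2)cc1` comes from compound 2 through a single change: 3-isopropyl-1,2,4-oxadiazol-5-yl in place of 5-isopropyl-1,3,4-oxadiazol-2-yl on an amine nitrogen in a ring. In words, this puts 3-isopropyl-1,2,4-oxadiazol-5-yl in place of 5-isopropyl-1,3,4-oxadiazol-2-yl on an amine nitrogen in a ring. Going by the values given here, the two measured compounds differ in more than one place, so no measured step isolates this swap. Even so, compound 1, which gives 70 nM, carries the same 3-isopropyl-1,2,4-oxadiazol-5-yl group that enters compound 3. A sizeable step towards a lower number, beyond the scatter, is therefore expected in this assay, although the data leave its size uncertain. The estimated change is a 6.7-fold lower number from compound 2 to compound 3 (0.82 log units; beyond the scatter). For compound 3 the expected value is 150 nM, with an estimated range from 40 nM to 600 nM.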

Compound 3, half-maximal inhibitory concentration: 30 nM
Estimate against measurement, compound 3: 5.0-fold (0.70 log units) above; measured number outside the range, below it.
By their numbers in this assay, from the lowest: compound 3; then compound 1; then compound 2.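

In this assay, the swap of 5-isopropyl-1,3,4-oxadiazol-2-yl for 3-isopropyl-1,2,4-oxadiazol-5-yl on an amine nitrogen in a ring now has a measured size: a 33-fold lower number from compound 2 to compound 3 (1.52 log units; beyond the scatter), a large step. Both groups have the same atoms and the same counts of hydrogen-bond donors and acceptors, so at this position the way the oxadiazole atoms are joined is enough to separate compound 2 and compound 3 by a wide margin. With 3-isopropyl-1,2,4-oxadiazol-5-yl held constant, diethylsulfamoyl in place of diethylcarbamoyl on an aromatic carbon gives only a modest step, a 2.3-fold lower number from compound 1 to compound 3 (0.37 log units; beyond the scatter), though one still beyond the scatter, and nothing available explains either step.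

The compounds shown leave open whether the oxadiazole swap would have a similar size with diethylcarbamoyl rather than diethylsulfamoyl on the aromatic carbon. They also leave open how the 3-substituent on the 1,2,4-oxadiazole tolerates change, for instance a cyclopropyl or tert-butyl group in place of isopropyl.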